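Swapping trifluoromethyl for nitro on a kinase inhibitor

The source may report more compounds than this note shows. Statements on the series, on what has been measured and on what is new or still open speak of the compounds shown alone.

Measured so far in an assay on isolated protein for inhibition of proto-oncogene tyrosine-protein kinase receptor Ret (Homo sapiens); on this read-out higher numbers stand for weaker inhibition and lower numbers for stronger inhibition:
- compound 1, `COc1ccc2c(c1)/C(=C/c1cc3c([nH]1)CCN(C(=O)N1CCN(C)CC1)C3)C(=O)N2`: 6 nM
- compound 2, `CC(=O)N1CCc2[nH]c(/C=C3\C(=O)Nc4ccc(C(F)(F)F)cc43)cc2C1`: 300 nM

Compound 2 has the higher of the two numbers, so it is the weaker inhibitor of the pair, and its value stands well apart from that of compound 1, beyond the usual scatter. The new compound 3, `CC(=O)N1CCc2[nH]c(/C=C3\C(=O)Nc4ccc([N+](=O)[O-])cc43)cc2C1`, keeps the whole framework of compound 2 and changes one group: nitro in place of trifluoromethyl on an aromatic carbon. Going by the values given here, no measured pair shows what such a swap does here, so there is no step to lean on. With that absence, the step from compound 2 to compound 3 is expected to be small, likely within the scatter, as a 1.5-fold lower number from compound 2 to compound 3 (0.18 log units; within the scatter) indicates. On that basis compound 3 is estimated at 200 nM, with a range from 50 nM to 800 nM.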

Compound 3, half-maximal inhibitory concentration: 73 nM
Compound 3: the middle estimate sits 2.7-fold (0.44 log units) above what was measured; the range from low to high includes it.
By their numbers in this assay, from the lowest: compound 1; then compound 3; then compound 2.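

Nitro in place of trifluoromethyl on this aromatic carbon gives a 4.1-fold lower number from compound 2 to compound 3 (0.61 log units; beyond the scatter) in this assay and so, with the rest of the framework held fixed, the group at this position does change the read-out. Going by these compounds alone, the step is modest, but it shows that this position is not indifferent to what it carries, which the earlier compounds could not show because no pair among them differed in one place. Nothing available here accounts for the gain, so this single pair records the change without explaining it.

The compounds shown leave open how a nitrile, an amine or a carboxylic acid would fare at this position. They also leave open whether the same swap would give a similar step on the framework of compound 1.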